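A few compounds are considered here, and "the series" means these few. Any claim that something is new, unique, unknown or untested is made for them only; others in the source may bear on it.

Among the compounds with values here, compound 2 `O=C(Nc1ccc(Cl)cc1)C1CCCN(C(=O)c2cc(C(F)(F)F)cc(C(F)(F)F)c2)C1` gives the higher of the two numbers so far in an ADME assay on PC-3 cells (Homo sapiens) for cytotoxicity, read by WST assay, tested at 100 uM; on this read-out higher numbers stand for more inhibition at the one concentration tested (going by the name of the read-out) and lower numbers for less inhibition: compound 2 shows 14%, while compound 1 `O=C(Nc1cccc(-c2ccco2)c1)C1CCCN(C(=O)c2cc(C(F)(F)F)cc(C(F)(F)F)c2)C1` shows 0%. Within the data shown here, the one measured step, a number 14 percentage points higher from compound 1 to compound 2 (beyond the scatter), was a modest rise beyond the scatter. Compound 3 `O=C(Nc1cccc(-c2cnco2)c1)C1CCCN(C(=O)c2cc(C(F)(F)F)cc(C(F)(F)F)c2)C1` is not yet measured. It differs from compound 2 in one place: 3-(1,3-oxazol-5-yl)phenyl in place of 4-chlorophenyl on an amide-type nitrogen. Among the measured compounds shown here, the only step that bears on this change is the one from compound 1 to compound 2, since the group entering in compound 3 resembles the 3-(furan-2-yl)phenyl of compound 1 in being a biaryl on the amide-type nitrogen. That step, a number 14 percentage points higher from compound 1 to compound 2 (beyond the scatter), ran in the opposite direction to the present change, so a modest fall in this assay is expected from compound 2 to compound 3, roughly a number 11 percentage points lower from compound 2 to compound 3 (beyond the scatter). Compound 3 is therefore estimated to give 3% in this assay, with a range from 0% to 15%.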

Compound 3, a percentage reported as inhibition, at one concentration (the size of the read-out at that concentration, not a potency): 9%
The estimate for compound 3 lay 6 percentage points below the measured number; measured number inside the range.
By their numbers in this assay, from the lowest: compounds 1, 3 and 2 (each within the scatter of the next, the first and the last beyond it).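

In this assay, 3-(1,3-oxazol-5-yl)phenyl in place of 4-chlorophenyl on the amide-type nitrogen gives a number 5 percentage points lower from compound 2 to compound 3 (within the scatter), so this biaryl group cannot be told apart from 4-chlorophenyl at this position. The second new comparison, 1,3-oxazol-5-yl in place of furan-2-yl on an aromatic carbon, gives a number 9 percentage points higher from compound 1 to compound 3 (within the scatter), so compound 3 also cannot be told apart from compound 1, even though compound 1 and compound 2 themselves differ beyond the scatter. No measurement offered here explains these readings.

The compounds shown leave open whether a carboxylic acid or a primary amine in place of the 1,3-oxazol-5-yl would shift the number beyond the scatter. They also leave open how the 4-chlorophenyl would compare with an unsubstituted phenyl at the same nitrogen.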